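Swapping Bromo for Hydroxy in a Small Benzamide

This account rests on a few compounds, and the source may have more. Where it says the series, first, only, none or still open, it means among the compounds named here.

Compound 1 `CC[C@H](CO)NC(=O)/C=C/c1ccccc1` — 211000 nM
Compound 2 `CC[C@H](CO)NC(=O)c1ccccc1Br` — "not determined" (no result reported)

Two compounds have been examined so far. In an ADME assay on HEK-293T cells (Homo sapiens) for cytotoxicity, read by MTT assay, with a stated time of 72 h (a higher number here means a weaker inhibitor, a lower number a stronger inhibitor), compound 1 gives 211000 nM, a very weak effect on the cells. Compound 2 shares the same amino-alcohol side chain but carries a bromo group on its aromatic ring, and in this assay compound 2 gives "not determined" (no result reported): no number is available for it, so it cannot be placed on the scale that compound 1 defines. Among the compounds with values here, with only one measured value there is also no step between measured compounds to lean on.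

The next compound, compound 3 `CC[C@H](CO)NC(=O)c1ccccc1O`, differs from compound 2 in one place: hydroxy in place of bromo on an aromatic carbon. Within the data shown here, no shift beyond the usual scatter is expected in this assay from this change, because compound 1 gives 211000 nM as the only reading available, and that reading shows how weak this family is in cells. Compound 3 is therefore expected to give about 200000 nM in this assay, within a range from 50000 nM to 500000 nM.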

Compound 3, half-maximal inhibitory concentration: 257000 nM
Compound 3: middle estimate off by 1.3-fold (0.11 log units), on the low side; the range from low to high includes it.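

Within the data shown here, compound 2 has no number in this assay, and no step from compound 2 to compound 3 can be read. On these data alone, what replacing bromo with hydroxy on the aromatic carbon does in this test therefore stays open. No supporting measurement is available to explain the reading for compound 3.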